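The source may report more compounds than this note shows. Statements on the series, on what has been measured and on what is new or still open speak of the compounds shown alone.

Measured so far in a functional assay on MGC-803 cells (Homo sapiens) for cytotoxicity, read by MTT assay, with a stated time of 48 h; on this read-out higher numbers stand for weaker inhibition and lower numbers for stronger inhibition:
- compound 1 `CC1=NN(C(=O)c2ccc(C)cc2)C(c2cc(Br)cc(Br)c2O)C1` gives 56500 nM 
- compound 2 `CCN(CC)CC(=O)N1N=C(C)CC1c1ccccc1OC(C)=O` gives 29500 nM 
- compound 3 `CC(=O)Oc1ccccc1C1CC(C)=NN1C(=O)CN(C(C)C)C(C)C` gives 20100 nM 

Compound 3 cannot be told apart from compound 2, but its number lies clearly under that of compound 1. Compound 4 `CC(=O)Oc1ccccc1C1CC(C)=NN1C(=O)CN1CCC(O)CC1` has 4-hydroxypiperidin-1-yl in place of diisopropylamino on a saturated chain carbon bound to a carbonyl carbon. For the measured compounds named here, the only measured step at that place is a 1.5-fold lower number from compound 2 to compound 3 (0.17 log units; within the scatter) and it joins two open-chain amino groups. Going by the values given here, no measured compound has a ring or a hydroxyl group there, so this guidance is thin. No step beyond the scatter is expected in this assay and the estimated change is a 1.2-fold higher number from compound 3 to compound 4 (0.09 log units; within the scatter) at the middle of the range. For compound 4 the estimated value is 25000 nM with an expected range from 10000 nM to 60000 nM in this measurement.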

Compound 4, half-maximal inhibitory concentration: 3510 nM
For compound 4 the middle estimate is 7.1-fold (0.85 log units) above the measured one; the measured number lies below the stated range.
By their numbers in this assay, from the lowest: compound 4; then compounds 3, 2 and 1 (each within the scatter of the next, the first and the last beyond it).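

In this assay the group on a saturated chain carbon bound to a carbonyl carbon now produces a step beyond the scatter: 4-hydroxypiperidin-1-yl replacing diisopropylamino gives a 5.7-fold lower number from compound 3 to compound 4 (0.76 log units; beyond the scatter) and replacing diethylamino gives an 8.4-fold lower number from compound 2 to compound 4 (0.92 log units; beyond the scatter). The two open-chain amino groups had not separated, whereas this ring-bearing, hydroxyl-bearing group does. No measurement here accounts for the change. Still open, as far as these compounds go, is whether the ring or the hydroxyl group carries the step: piperidin-1-yl without the hydroxyl, or open-chain bis(2-hydroxyethyl)amino, would separate the two.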